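A few compounds are considered here, and "the series" means these few. Any claim that something is new, unique, unknown or untested is made for them only; others in the source may bear on it.

Measured so far:
compound 1 `COc1cccc(OC)c1OCCNCCOc1ccccc1OCc1cccc(Cl)c1`: 20400 nM
compound 2 `COc1cccc(OC)c1OCCNCCOc1ccccc1OCc1cccc(C)c1`: 32300 nM

In a functional assay on PC-3 cells (Homo sapiens) for cytotoxicity, read by sulforhodamine B assay (on this read-out lower numbers stand for stronger inhibition of growth and higher numbers for weaker inhibition of growth), compound 2 gives 32300 nM, the higher of the two numbers but only a 1.6-fold higher number from compound 1 to compound 2 (0.20 log units; within the scatter), so the pair is not separated. Compound 3 `COc1cccc(OC)c1OCCNCCOc1ccccc1OCc1ccccc1[N+](=O)[O-]` carries 2-nitrophenyl in place of 3-methylphenyl on a saturated chain carbon bound to an oxygen on an aromatic ring. Going by the values given here, the only measured step also exchanges the substituent on this ring and stayed within the scatter; no measured step moves a substituent to a different ring carbon, so that part of the change is uncovered. For compound 3 no step beyond the scatter is expected in this assay, that is a 1.3-fold lower number from compound 2 to compound 3 (0.11 log units; within the scatter). Compound 3 is estimated at 25000 nM, range 9000 nM to 70000 nM.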

Compound 3, concentration for total growth inhibition: 34700 nM
For compound 3 the middle estimate is 1.4-fold (0.14 log units) below the measured one, and the stated range covers the measured number.
By their numbers in this assay, from the lowest: compounds 1, 2 and 3 (each within the scatter of the next).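

In this assay, 2-nitrophenyl in place of 3-methylphenyl gives a 1.1-fold higher number from compound 2 to compound 3 (0.03 log units; within the scatter), and 2-nitrophenyl in place of 3-chlorophenyl gives a 1.7-fold higher number from compound 1 to compound 3 (0.23 log units; within the scatter). The place on a saturated chain carbon bound to an oxygen on an aromatic ring thus tolerates a change that brings in 2 hydrogen-bond acceptors and a different substitution position, with all three compounds unseparated. Nothing available explains this flat result.

Going by these compounds, whether 3-nitrophenyl reads the same as 2-nitrophenyl remains open, so the substituent and its position stay confounded. Also open, on these data alone, is whether an amine or carboxylic acid on this ring, or a longer chain, would give a step beyond the scatter.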